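Methoxy Exchanged for Chloro on the Benzyl Ring

The source may hold more compounds than are shown below. What is called first, only, known or untested is meant among the compounds shown, and "the series" means these compounds.

Compound 1 `CCN(Cc1ccccc1F)C(=O)C1CCN(S(=O)(=O)c2ccc3cn[nH]c3c2)CC1` gives 84% in a functional assay on CHO cells for positive allosteric modulation of muscarinic acetylcholine receptor M5 (Homo sapiens), read by calcium flux; a lower number here means a smaller maximal response, a higher number a larger maximal response.
Compound 2 `CCN(Cc1ccccc1OC)C(=O)C1CCN(S(=O)(=O)c2ccc3cn[nH]c3c2)CC1` gives 92% in this assay.

Compound 2 carries the higher of the two numbers, but the step of a number 8 percentage points higher from compound 1 to compound 2 (within the scatter) lies within the scatter, so the two compounds are not told apart in this assay. Compound 3 `CCN(Cc1ccccc1Cl)C(=O)C1CCN(S(=O)(=O)c2ccc3cn[nH]c3c2)CC1` differs from compound 2 by chloro in place of methoxy on an aromatic carbon. For the measured compounds named here, the only measured step that bears on this exchange, the one from compound 1 to compound 2 at the same position, stayed within the scatter. Compound 3 is therefore expected to show no step beyond the scatter, a number 6 percentage points lower from compound 2 to compound 3 (within the scatter). Compound 3 is estimated at 86%, between 72% and 100%.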

Compound 3, largest response reached (reported as percent of maximum), in percent of the reference or control that the assay uses: 93%
Compound 3: the middle estimate sits 7 percentage points below what was measured, and the stated range covers the measured number.
By their numbers in this assay, from the lowest: compounds 1, 2 and 3 (each within the scatter of the next).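

Chloro in place of methoxy gives a number 1 percentage points higher from compound 2 to compound 3 (within the scatter) and chloro in place of fluoro gives a number 9 percentage points higher from compound 1 to compound 3 (within the scatter) at this same place on the aromatic ring. Fluoro, methoxy and chloro, ortho to a large group, are thus not told apart in this assay, even though the swap from methoxy to chloro changes the heavy-atom count and removes a hydrogen-bond acceptor. Nothing at hand offers an explanation for this flat result.

The compounds shown leave open whether an amine, a carboxylic acid or a longer chain at this place would move the response beyond the scatter.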